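A few compounds are considered here, and "the series" means these few. Any claim that something is new, unique, unknown or untested is made for them only; others in the source may bear on it.

Compound 1 `Cc1cc(C)c(S(=O)(=O)N2CCC(N3CCN(C)CC3)CC2)c(C)c1` stands in an ADME assay on HCT-116 cells (Homo sapiens) for cytotoxicity, read by CellTiter-Glo, with a stated time of 72 h (a higher number here means a weaker inhibitor, a lower number a stronger inhibitor), with two relatives, compound 2 `Cc1cc(C)c(S(=O)(=O)c2ccc(N3CCC(C)CC3)cc2)c(C)c1` and compound 3 `Cc1cc(C)c(S(=O)(=O)NC2CCN(C3CCN(C)CC3)CC2)c(C)c1`. Compound 1 gives > 5000 nM, which is a limit of the assay and not a number. Compound 2 gives > 5000 nM, again a limit. Compound 3 gives > 5000 nM, also a limit. The whole record so far is therefore (the limit of > 5000 nM in this assay, at which 3 of the 3 values shown sit), and no pair among these compounds differs in one place only.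

Compound 4 `Cc1cc(C)c(S(=O)(=O)N2CCC(N3CCC(O)CC3)CC2)c(C)c1` carries 4-hydroxypiperidin-1-yl in place of 4-methylpiperazin-1-yl on a saturated ring carbon, a change counted as 4-hydroxypiperidin-1-yl in place of 4-methylpiperazin-1-yl on a saturated ring carbon. No step beyond the scatter is expected from this change in this assay, so compound 4 would be expected to remain near the limit. That expectation rests on compound 1, whose limit is > 5000 nM. The expected step is a step that the limit leaves unreadable from compound 1 to compound 4. For compound 4 the estimate is 7000 nM, with an expected range from 4000 nM to 15000 nM.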

Compound 4, half-maximal inhibitory concentration: > 5000 nM
Compound 4: only a limit was reported; the forecaster's own chance of this, stated with the estimate: 85%; the middle value lies beyond the limit too.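

In this assay, going by these compounds alone, compound 1 and compound 4 both give only a limit of the assay, so no step between them can be read. The compounds shown leave open whether any structural change among them would bring a value within the measurable range.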